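A few compounds are considered here, and "the series" means these few. Any claim that something is new, unique, unknown or untested is made for them only; others in the source may bear on it.

Compound 1, `CN(C)CCn1cnnc1-c1cc(Oc2ccc(NC(=O)N/N=C/c3ccc(O)cc3)cc2F)ccn1`, gives 1920 nM in a functional assay on HT-29 cells (Homo sapiens) for cytotoxicity, read by MTT assay, with a stated time of 72 h; on this read-out lower numbers stand for stronger inhibition and higher numbers for weaker inhibition.
Compound 2, `CN(C)CCn1cnnc1-c1cc(Oc2ccc(NC(=O)N/N=C/c3c[nH]c4ccccc34)cc2F)ccn1`, gives 1300 nM in this assay.
Compound 3, `CN(C)CCn1cnnc1-c1cc(Oc2ccc(NC(=O)N/N=C/c3ccc(F)cc3F)cc2F)ccn1`, gives 960 nM in this assay.

Compound 1 carries the highest of the three numbers, yet the steps of a 1.5-fold lower number from compound 1 to compound 2 (0.17 log units; within the scatter) and a 2.0-fold lower number from compound 1 to compound 3 (0.30 log units; within the scatter) both stay within the scatter, so none of the three can be called more or less active than another. Compound 4, `CN(C)CCn1cnnc1-c1cc(Oc2ccc(NC(=O)N/N=C/c3ccc(O)cc3O)cc2F)ccn1`, differs from compound 1 by hydroxy in place of hydrogen on an aromatic carbon. Within the data shown here, no measured step tests this particular change; each of the three measured steps swaps the whole ring that carries the hydroxy, and all of them stay within the scatter. The expectation for compound 4 is therefore a step of a 1.1-fold lower number from compound 1 to compound 4 (0.03 log units; within the scatter), no larger than the scatter. Compound 4 is estimated at 1800 nM, with a range from 800 nM to 4000 nM.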

Compound 4, half-maximal inhibitory concentration: 52600 nM
Estimate against measurement, compound 4: 29-fold (1.47 log units) below; measured number above the stated range.
By their numbers in this assay, from the lowest: compounds 3, 2 and 1 (each within the scatter of the next); then compound 4.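

Among the earlier compounds, whole rings could be exchanged with every step staying within the scatter, but adding one hydroxy ortho to a large group gives (a 27-fold higher number from compound 1 to compound 4 (1.44 log units; beyond the scatter)). So a single added group on this ring can matter far more than those ring swaps did. The 2,4-dihydroxyphenyl ring also stands apart from the other two rings, with (a 55-fold higher number from compound 3 to compound 4 (1.74 log units; beyond the scatter)) and (a 40-fold higher number from compound 2 to compound 4 (1.61 log units; beyond the scatter)), and no measurement here explains this.

From the compounds shown here alone, whether the loss belongs to the hydroxy itself or to any added group at this place stays open. A methoxy or an amine in its place, or a 2-hydroxyphenyl ring, would help separate these possibilities.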